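The compounds below may be only part of what the source reports. "The series", "measured", "known", "first", "only" and "open" are said of these compounds alone.

Compound 1 `Cc1ccc(C(=O)CSc2nnc(C)n2N2C(=O)c3ccccc3C2=O)cc1` and compound 2 `CCc1nnc(SCc2ccccc2)n1N1C(=O)c2ccccc2C1=O` share one core. In a functional assay on A549 cells (Homo sapiens) for cytotoxicity, read by MTT assay, with a stated time of 48 h (a lower number here means a stronger inhibitor, a higher number a weaker inhibitor), compound 1 returns only a limit, > 200000 nM. In this assay compound 2 likewise returns only a limit, > 200000 nM. Both measured values sit at the limit of > 200000 nM in this assay, at which 2 of the 2 values shown sit, so compound 2 stands level with the other measured compound and no number places it. Compound 3 `CCc1nnc(SCC(=O)c2ccc(C)cc2)n1N1C(=O)c2ccccc2C1=O` differs from compound 2 by (4-methylphenyl)carbonyl in place of phenyl on a saturated chain carbon bound to a sulfur. Among the measured compounds shown here, no step between measured compounds is available, and compound 1 already carries the entering group at a limit > 200000 nM. Compound 3 is therefore expected to stay at the limit, with an expected step that the limit leaves unreadable from compound 2 to compound 3 of none beyond the scatter. The estimate for compound 3 is 300000 nM, in the range 100000 nM to 1000000 nM.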

Compound 3, half-maximal inhibitory concentration: > 200000 nM
Compound 3: a limit, no number; the forecaster's own chance of this, stated with the estimate: 85%; the middle value does not contradict the limit.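

In this assay compound 3 returns only a limit, > 200000 nM, so no step from compound 1 or compound 2 to compound 3 can be read: the limit of > 200000 nM in this assay, at which 3 of the 3 values shown sit.

The compounds shown leave open whether any change on the shared core gives a number rather than a limit in this assay.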